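Acrylamide series: chain branching and aryl ether variation

This account rests on a few compounds, and the source may have more. Where it says the series, first, only, none or still open, it means among the compounds named here.

Measured in a functional assay on PC-3 cells (Homo sapiens) for antiproliferative activity, read by MTT assay, with a stated time of 72 h; on this read-out lower numbers stand for stronger inhibition and higher numbers for weaker inhibition:
- compound 1 `CC/C=C/C(=O)Nc1cc2c(N3CCc4ccccc43)ncnc2cc1OC`: 5890 nM
- compound 2 `CCC/C=C/C(=O)Nc1cc2c(N3CCc4ccccc43)ncnc2cc1OC`: 4240 nM
- compound 3 `CC/C=C/C(=O)Nc1cc2c(N3CCc4ccccc43)ncnc2cc1O[C@@H]1CCOC1`: 9590 nM

Compound 2 differs from compound 1 by methyl in place of hydrogen on a saturated chain carbon, two bonds along the chain from a double-bonded chain carbon, giving a 1.4-fold lower number from compound 1 to compound 2 (0.14 log units; within the scatter). The cores of compound 1 and compound 3 differ by oxolan-3-yl in place of methyl on an oxygen on an aromatic ring, giving a 1.6-fold higher number from compound 1 to compound 3 (0.21 log units; within the scatter). Compound 4 `CC(C)/C=C/C(=O)Nc1cc2c(N3CCc4ccccc43)ncnc2cc1O[C@@H]1CCOC1` is not yet measured; it differs from compound 3 by methyl in place of hydrogen on a saturated chain carbon bound to a double-bonded chain carbon and a saturated chain carbon. This is the same kind of change as from compound 1 to compound 2, but the place differs: in compound 4 the methyl enters on a saturated chain carbon bound to a double-bonded chain carbon and a saturated chain carbon, whereas from compound 1 to compound 2 it entered on a saturated chain carbon two bonds along the chain from a double-bonded chain carbon. For compound 4 a step of about a 1.3-fold lower number from compound 3 to compound 4 (0.11 log units; within the scatter) in this assay is expected, resting on a 1.4-fold lower number from compound 1 to compound 2 (0.14 log units; within the scatter) for compound 2. Compound 4 is estimated at 7500 nM, with a range from 3500 nM to 16000 nM.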

Compound 4, half-maximal inhibitory concentration: 11200 nM
Compound 4: the middle estimate sits 1.5-fold (0.17 log units) below what was measured; measured number inside the range.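

In this assay, methyl in place of hydrogen on a saturated chain carbon bound to a double-bonded chain carbon and a saturated chain carbon gives a 1.2-fold higher number from compound 3 to compound 4 (0.07 log units; within the scatter). Set beside the earlier methyl step, this step shows no measurable difference between the two cores: the same change on two cores in this assay, a 1.4-fold lower number (0.14 log units; within the scatter) from compound 1 to compound 2 and a 1.2-fold higher number (0.07 log units; within the scatter) from compound 3 to compound 4, 1.6-fold (0.21 log units) apart, within the scatter of two such steps. This shows that the methyl change stays small on both cores, but it does not establish a transferable increment: each core supplies a single pair, and the methyl enters at a different place in each.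

Still open, from the compounds shown here alone, is whether an amine or a longer chain in place of the ethyl or isopropyl group would move the number beyond the scatter. Also open, going by these compounds, is how the isopropyl group behaves on the core of compound 1.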